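The source may report more compounds than this note shows. Statements on the series, on what has been measured and on what is new or still open speak of the compounds shown alone.

Compounds measured so far:
- compound 1 `COc1ccc(-c2noc(CN3N=N[C@@H]4C(=O)N(c5ccccc5)C(=O)[C@@H]43)n2)cc1`: > 100 ug/mL (a limit)
- compound 2 `O=C1[C@H]2N=NN(Cc3nc(-c4ccc(I)cc4)no3)[C@H]2C(=O)N1c1ccccc1`: 48.6 ug/mL
- compound 3 `CN(C)c1ccc(-c2noc(CN3N=N[C@@H]4C(=O)N(c5ccccc5)C(=O)[C@@H]43)n2)cc1`: > 100 ug/mL (a limit)

In an ADME assay on L6 cells (Rattus norvegicus) for cytotoxicity, read by resazurin assay, with a stated time of 72 h (on this read-out lower numbers stand for stronger inhibition and higher numbers for weaker inhibition), compound 3 gives only a limit, > 100 ug/mL. Compound 3 thus stands at the limit of > 100 ug/mL in this assay, at which 2 of the 3 values shown sit.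

The next compound, compound 4 `O=C1[C@H]2N=NN(Cc3nc(-c4ccc(C(F)(F)F)cc4)no3)[C@H]2C(=O)N1c1ccccc1`, carries trifluoromethyl in place of dimethylamino on an aromatic carbon, para to a large group: trifluoromethyl in place of dimethylamino on an aromatic carbon.

Within the data shown here, no measured step makes this exact exchange, but three change the same position. Iodo in place of methoxy gave an at least 2.0-fold lower number from compound 1 to compound 2 (0.31 log units; beyond the scatter). Dimethylamino in place of iodo gave an at least 2.0-fold higher number from compound 2 to compound 3 (0.31 log units; beyond the scatter). Dimethylamino in place of methoxy gave a step that the two limits leave unreadable from compound 1 to compound 3. Only compound 2, at 48.6 ug/mL, shows a number, so a modest move towards that value is expected in this assay. Compound 4 may also end up at the limit.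

The expected change is an at least 1.5-fold lower number from compound 3 to compound 4 (0.18 log units; that floor lies within the scatter). Compound 4 is estimated at 65 ug/mL. The expected range for compound 4 runs from 30 ug/mL to 120 ug/mL.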

Compound 4, half-maximal inhibitory concentration: 44.4 ug/mL
The estimate for compound 4 lay 1.5-fold (0.17 log units) above the measured number; measured number inside the range.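

In this assay, trifluoromethyl in place of dimethylamino gives an at least 2.2-fold lower number from compound 3 to compound 4 (0.35 log units; beyond the scatter), and trifluoromethyl in place of methoxy gives an at least 2.2-fold lower number from compound 1 to compound 4 (0.35 log units; beyond the scatter). Against iodo, the same position gives a 1.1-fold lower number from compound 2 to compound 4 (0.04 log units; within the scatter), so compound 2 is no longer the only compound here with a readable number, and compound 4 cannot be told apart from it. Compound 1 and compound 3 remain limits, not numbers: the limit of > 100 ug/mL in this assay, at which 2 of the 4 values shown sit.

As far as these compounds go, the steps from compound 1 and compound 3 give only minimum sizes, so their true distance from compound 2 and compound 4 stays open. From the compounds shown here alone, it is also open whether a nitrile, a carboxylic acid or a plain hydrogen at this position would sit with compound 2 and compound 4 or reach the limit.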